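Pyridinyl Amide in Place of Methoxyphenyl Amide

The source may report more compounds than this note shows. Statements on the series, on what has been measured and on what is new or still open speak of the compounds shown alone.

Compound 1 `Cc1ccc(S(=O)(=O)NCc2ccc(CNC(=O)c3ccccc3)cc2)cc1`: > 1000 nM, a limit of the assay
Compound 2 `COc1ccccc1C(=O)NCc1ccc(CNS(=O)(=O)c2ccc(C)cc2)cc1`: 100 nM

Among the measured compounds shown here, compound 2 holds the only number measured in an assay on MDA-MB-231 cells for binding affinity to C-X-C chemokine receptor type 4 (Homo sapiens), read by immunofluorescence and microscopy, with stated times of 10 min and 30 min; on this read-out higher numbers stand for an effect only at larger amounts of compound and lower numbers for an effect already at smaller amounts; the other value is a limit (the limit of > 1000 nM in this assay, at which 1 of the 2 values shown sits). For the measured compounds named here, the single measured step, an at least 10-fold lower number from compound 1 to compound 2 (1.00 log units; beyond the scatter), is the one that bears here, as it introduced the methoxy that compound 3 `Cc1ccc(S(=O)(=O)NCc2ccc(CNC(=O)c3cccnc3)cc2)cc1` no longer carries: pyridin-3-yl in place of 2-methoxyphenyl on a carbonyl carbon. As far as these compounds go, a rise in the number is therefore expected, likely beyond the scatter, though the new ring is untested. Compound 3 is estimated at 600 nM, between 150 nM and 3000 nM. The expected step is a 6.0-fold higher number from compound 2 to compound 3 (0.78 log units; beyond the scatter).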

Compound 3, effective concentration (reported as EC, without a stated level of effect): > 1000 nM
Compound 3 gave a limit, no number (the forecaster's own chance of this, stated with the estimate: 40%); at least 1.6-fold (0.22 log units) between middle value and limit.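

Pyridin-3-yl in place of 2-methoxyphenyl on a carbonyl carbon gives an at least 10-fold higher number from compound 2 to compound 3 (1.00 log units; beyond the scatter). Both groups count one hydrogen-bond acceptor and one six-membered aromatic ring, so these counts alone do not preserve the value at this position. The step from the phenyl amide to the pyridin-3-yl amide cannot be read, and phenyl and pyridin-3-yl cannot be ordered: the limit of > 1000 nM in this assay, at which 2 of the 3 values shown sit.

The compounds shown leave open whether an ethoxy or an amine in place of the methoxy would serve equally. As far as these compounds go, whether a methoxy on the pyridin-3-yl ring would restore a measurable value also remains open.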